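Moving the aromatic ring one bond out from the sulfonyl

This account rests on a few compounds, and the source may have more. Where it says the series, first, only, none or still open, it means among the compounds named here.

Two compounds of a shared core, differing only in the group on a sulfonyl sulfur, have been measured in a functional assay on RH7777 cells for antagonist activity at lysophosphatidic acid receptor 2 (Homo sapiens), read by calcium flux; a higher number here means a weaker inhibitor, a lower number a stronger inhibitor. Compound 1 `CCCCS(=O)(=O)N1CCN(C[C@H](C)Nc2ncnc3c(C)csc23)CC1` carries a butyl group there and gives 6610 nM. Compound 2 `Cc1cccc(S(=O)(=O)N2CCN(C[C@H](C)Nc3ncnc4c(C)csc34)CC2)c1` carries a 3-methylphenyl group in the same place and gives 310 nM, the lowest of the two numbers; the step of a 21-fold lower number from compound 1 to compound 2 (1.33 log units; beyond the scatter) shows how much the aromatic group gains over the chain.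

Compound 3 `Cc1csc2c(N[C@@H](C)CN3CCN(S(=O)(=O)Cc4ccccc4)CC3)ncnc12` is the next variation: benzyl in place of 3-methylphenyl on a sulfonyl sulfur. The atoms are the same, only joined differently, so the aromatic ring is kept but set one bond further from the sulfonyl sulfur. Going by the values given here, no measured pair shows this exact change, and the only step that bears on it, from compound 1 to compound 2, says that an aromatic group directly on the sulfur is strongly preferred over a plain chain. A benzyl group sits between those two cases, so the expectation is a loss of potency for compound 3, smaller than the whole gap between compound 1 and compound 2, with the step of a 3.9-fold higher number from compound 2 to compound 3 (0.59 log units; beyond the scatter) estimated. For compound 3 the expected result in this assay is 1200 nM, within a range from 350 nM to 4500 nM.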

Compound 3, half-maximal inhibitory concentration: 1860 nM
Beside the measured number, compound 3's estimate is 1.6-fold (0.19 log units) below it; measured number inside the range.
By their numbers in this assay, from the lowest: compound 2; then compound 3; then compound 1.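

In this assay, going by these compounds alone, the 3-methylphenyl and benzyl groups have the same atom count and the same six-membered aromatic ring of carbon only, yet the swap gives a modest loss (a 6.0-fold higher number from compound 2 to compound 3 (0.78 log units; beyond the scatter)), so at this place on the sulfonyl sulfur it matters how the ring is attached, not only that a ring is present. The ring still pays off when it is set one bond further out, since replacing the propyl part of the butyl group with phenyl gives a modest gain (a 3.6-fold lower number from compound 1 to compound 3 (0.55 log units; beyond the scatter)), though less than the full gain seen with compound 2. Nothing measured here explains why the way the ring is attached changes the number so much.

Going by these compounds, the swap from compound 2 to compound 3 moves the ring and removes its methyl group in one step, so the share of each change in the loss remains open. A plain phenyl group directly on the sulfonyl sulfur would help separate those two changes, and a 2-phenylethyl group would show whether moving the ring still further out continues the loss.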